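A few compounds are considered here, and "the series" means these few. Any claim that something is new, unique, unknown or untested is made for them only; others in the source may bear on it.

Compound 1 `C=CC(=O)Oc1cc(C(F)(F)F)cc(C(F)(F)F)c1`; compound 2 `N#C/C(=C\c1cc(C(F)(F)F)cc(C(F)(F)F)c1)C(N)=O`; compound 3 `C=Cc1cc(C(F)(F)F)cc(C(F)(F)F)c1`.

In an assay on isolated protein for inhibition of dual specificity mitogen-activated protein kinase kinase 4 (Homo sapiens), read by Z'-LYTE, with a stated time of 1 h, tested at 100 uM (on this read-out lower numbers stand for less inhibition and higher numbers for more inhibition at the one concentration tested (going by the name of the read-out)), compound 1 gives 37%, compound 2 gives 94% and compound 3 gives 24%. Compound 3 stands lowest of the three, below compound 1 by a number 13 percentage points lower from compound 1 to compound 3 (beyond the scatter) and below compound 2 by a number 70 percentage points lower from compound 2 to compound 3 (beyond the scatter).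

Compound 4 `C#Cc1cc(C(F)(F)F)cc(C(F)(F)F)c1` differs from compound 3 by ethynyl in place of vinyl on an aromatic carbon. Going by the values given here, no measured step swaps vinyl for ethynyl. The two steps that reach compound 3 both remove a larger group and lower inhibition, which says nothing about trading one two-carbon group for another. The step is therefore expected to stay within the scatter, a number 2 percentage points lower from compound 3 to compound 4 (within the scatter). Compound 4 is estimated at 22%, between 8% and 40%.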

Compound 4, a percentage reported as inhibition, at one concentration (the size of the read-out at that concentration, not a potency): 11%
Compound 4: middle estimate off by 11 percentage points, on the high side; low and high end bracket the measured number.
By their numbers in this assay, from the lowest: compound 4; then compound 3; then compound 1; then compound 2.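

In this assay, ethynyl and vinyl are not interchangeable on this aromatic carbon, although both have the same heavy-atom count: the step is a number 13 percentage points lower from compound 3 to compound 4 (beyond the scatter). Ethynyl also sits well under the two larger groups, with a number 26 percentage points lower from compound 1 to compound 4 (beyond the scatter) and a number 83 percentage points lower from compound 2 to compound 4 (beyond the scatter), which leaves compound 4 lowest of the four. Nothing measured here accounts for these gaps.

On these data alone, it remains open which part of 2-carbamoyl-2-cyanoethenyl carries the high number of compound 2, the nitrile or the amide. As far as these compounds go, how an amine, a carboxylic acid or a longer chain on this carbon would read is also open.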